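Notes on the step from compound 3 to compound 4

A few compounds are considered here, and "the series" means these few. Any claim that something is new, unique, unknown or untested is made for them only; others in the source may bear on it.

In a functional assay on cells (Erythrocyte, Rattus norvegicus) for inhibition, read by hemolysis, with a stated time of 1 h (a higher number here means a weaker inhibitor, a lower number a stronger inhibitor), compound 1 `COc1cc(OC)c(OC)cc1/C=C/C(=O)c1ccc(Cl)cc1` gives 2.3 ug/mL, compound 2 `COc1ccc(C(=O)/C=C/c2cc(OC)c(OC)cc2OC)cc1` gives 2.18 ug/mL and compound 3 `COc1cc(OC)c(OC)cc1/C=C/C(=O)c1cc(Cl)ccc1O` gives 2.23 ug/mL, so compound 3 stands level with the other two within the scatter. Compound 4 `COc1cc(OC)c(OC)cc1/C=C/C(=O)c1ccc(C)cc1` has 4-methylphenyl in place of 5-chloro-2-hydroxyphenyl on a carbonyl carbon. Among the measured compounds shown here, three measured steps bear on this change: a 1.0-fold lower number from compound 1 to compound 3 (0.01 log units; within the scatter), a 1.0-fold higher number from compound 2 to compound 3 (0.01 log units; within the scatter) and a 1.1-fold lower number from compound 1 to compound 2 (0.02 log units; within the scatter), all within the scatter. For the measured compounds named here, no measured compound carries 4-methylphenyl, so no step beyond the scatter is expected in this assay. The expected change is a 1.0-fold lower number from compound 3 to compound 4 (0.01 log units; within the scatter). The estimate for compound 4 is 2.2 ug/mL, with an expected range of 1.3 ug/mL to 3.6 ug/mL.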

Compound 4, half-maximal inhibitory concentration: 2.24 ug/mL
For compound 4 the middle estimate is 1.0-fold (0.01 log units) below the measured one, within the range that was stated.
By their numbers in this assay, from the lowest: compounds 2, 3, 4 and 1 (each within the scatter of the next).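

In this assay, 4-methylphenyl on the carbonyl carbon gives a 1.0-fold higher number from compound 3 to compound 4 (0.00 log units; within the scatter) even though the chlorine and the hydroxyl of 5-chloro-2-hydroxyphenyl are gone, so a group with no hydrogen-bond donor or acceptor reads level here. Methyl in place of methoxy gives a 1.0-fold higher number from compound 2 to compound 4 (0.01 log units; within the scatter) and methyl in place of chloro gives a 1.0-fold lower number from compound 1 to compound 4 (0.01 log units; within the scatter) on the same aromatic carbon, which extends the flat reading to an all-carbon group. Nothing available explains this flat reading.

Still open, on these data alone, is whether an amine, a carboxylic acid or a longer chain on this ring would produce any step beyond the scatter.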